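Three Inactive Amides and a Fourth Chain Variant

A few compounds are considered here, and "the series" means these few. Any claim that something is new, unique, unknown or untested is made for them only; others in the source may bear on it.

Three compounds built on a shared core were tested in an assay on isolated protein for inhibition of thyroid hormone receptor beta (Homo sapiens), read by fluorescence polarization; on this read-out lower numbers stand for stronger inhibition and higher numbers for weaker inhibition. Compound 1, `Cc1ccc(N2CCN(C(=O)C3CCN(C(=O)c4ccc(S(C)(=O)=O)c([N+](=O)[O-])c4)CC3)CC2)cc1`, reached only the limit of the assay, reported as > 60000 nM. Compound 2, `CC(C)N(C(=O)CCNC(=O)c1ccc(S(C)(=O)=O)c([N+](=O)[O-])c1)C(C)C`, likewise gave only a limit, > 60000 nM. Compound 3, `CN(CC(=O)N1CCc2ccccc2C1)C(=O)c1ccc(S(C)(=O)=O)c([N+](=O)[O-])c1`, also stopped at a limit, > 60000 nM. So compound 2 stands nowhere distinct among the numbers shown: every one of the three values is a limit rather than a number, as recorded in the limit of > 60000 nM in this assay, at which 3 of the 3 values shown sit.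

Compound 4, `CS(=O)(=O)c1ccc(C(=O)NCCCC(=O)N2CCCCC2)cc1[N+](=O)[O-]`, has not yet been tested in this assay. It differs from compound 2 in one place: ((piperidin-1-yl)carbonyl)methyl in place of diisopropylcarbamoyl on a saturated chain carbon, two bonds along the chain from an amide-type nitrogen. For the measured compounds named here, since no measured step between compounds exists here, and all three known values sit at the same limit, the change from compound 2 to compound 4 is expected to bring no shift beyond the scatter, and the expected step is a number no higher from compound 2 to compound 4 (the limit leaves the size open). Compound 4 is therefore estimated at 60000 nM, most likely again only a limit, within a range from 20000 nM to 200000 nM.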

Compound 4, half-maximal inhibitory concentration: > 60000 nM
Compound 4 gave a limit, no number; the forecaster's own chance of this, stated with the estimate: 85%; the middle value lies on the limit itself.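

Compound 2 and compound 4 each gave a limit rather than a number, so no step between them can be read: the limit of > 60000 nM in this assay, at which 4 of the 4 values shown sit.

The compounds shown leave open what true number any of the four would give in this assay, and which change to the shared core, if any, would yield a readable value.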